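A few compounds are considered here, and "the series" means these few. Any claim that something is new, unique, unknown or untested is made for them only; others in the source may bear on it.

Working notes on the series. The reference point is compound 1 `O=[N+]([O-])c1ccc(S(=O)(=O)Nc2cnccn2)cc1`. In an ADME assay on J774 cells (Mus musculus) for cytotoxicity, read by resazurin assay, with a stated time of 24 h (on this read-out higher numbers stand for weaker inhibition and lower numbers for stronger inhibition), compound 1 reaches only a limit of the assay, > 256000 nM, so no single number is known for it. Among the values shown, compound 1 therefore sits at the limit of > 256000 nM in this assay, at which 1 of the 2 values shown sits. Compound 2 `O=S(=O)(Nc1cnccn1)c1ccc(Cl)cc1` gives "not determined" (no result reported) in this assay and adds nothing to the comparison.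

The compound still to be measured is compound 3 `Cc1cc(NS(=O)(=O)c2ccc([N+](=O)[O-])cc2)no1`. Against compound 1 the change is 5-methyl-1,2-oxazol-3-yl in place of pyrazin-2-yl on a sulfonamide nitrogen, the rest of compound 1 being kept. For the measured compounds named here, no measured step between two compounds exists in this assay, so the size of the step from compound 1 can only be anticipated, not read off. The step of a number no higher from compound 1 to compound 3 (the limit leaves the size open) is expected to be none beyond the scatter. For compound 3 the estimate in this assay is 256000 nM, with a range from 100000 nM to 600000 nM. A result reported again as a limit rather than as a number is expected to be the likelier outcome for compound 3.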

Compound 3, half-maximal inhibitory concentration: > 256000 nM
Compound 3 gave a limit, no number (the forecaster's own chance of this, stated with the estimate: 75%); the middle value lies on the limit itself.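

In this assay, for the compounds shown here, compound 1 and compound 3 each give a limit rather than a number, so no step between the two can be read. The compounds shown leave open how far either lies from that limit, and whether 5-methyl-1,2-oxazol-3-yl in place of pyrazin-2-yl changes the read-out at all. The values gather at one point: the limit of > 256000 nM in this assay, at which 2 of the 3 values shown sit.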